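Fluoro Added Next to the Sulfamoylamino Group

The compounds below may be only part of what the source reports. "The series", "measured", "known", "first", "only" and "open" are said of these compounds alone.

Measured compounds:
compound 1 `NC(=O)c1c(Nc2ccc(I)cc2F)cc(F)cc1Oc1cccc(NS(N)(=O)=O)c1` — 180 nM
compound 2 `CCNS(=O)(=O)Nc1cccc(Oc2cc(F)cc(Nc3ccc(I)cc3F)c2C(N)=O)c1` — 287 nM

Both were tested in a functional assay on HCT-116 cells (Homo sapiens) for antiproliferative activity; a lower number here means a stronger inhibitor, a higher number a weaker inhibitor. Among the measured compounds shown here, compound 1 gives 180 nM, the lowest of the two numbers, though its only neighbour, compound 2, sits within the scatter: the change a 1.6-fold higher number from compound 1 to compound 2 (0.20 log units; within the scatter) came with ethyl in place of hydrogen on a sulfonamide nitrogen.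

Compound 3 `NC(=O)c1c(Nc2ccc(I)cc2F)cc(F)cc1Oc1ccc(F)c(NS(N)(=O)=O)c1` has not yet been measured. It differs from compound 1 by fluoro in place of hydrogen on an aromatic carbon. For the measured compounds named here, no measured step touches that aromatic carbon, so nothing directly bears on this change; the single step available, from compound 1 to compound 2, sat elsewhere and stayed within the scatter. For compound 3 a step of no change at the digits printed from compound 1 to compound 3 (within the scatter) is therefore expected, no more than the scatter in either direction. Compound 3 is estimated at 180 nM, within a range of 80 nM to 400 nM.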

Compound 3, half-maximal inhibitory concentration: 2510 nM
The estimate for compound 3 lay 14-fold (1.14 log units) below the measured number; the measured number lies above the stated range.
By their numbers in this assay, from the lowest: compounds 1 and 2 (each within the scatter of the next); then compound 3.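

In this assay, the aromatic carbon ortho to a sulfamoylamino group and para to a large group turns out to be sensitive to substitution: fluoro in place of hydrogen there gives a 14-fold higher number from compound 1 to compound 3 (1.14 log units; beyond the scatter). Among the compounds shown here, this one added heavy atom, with no ring and no hydrogen-bond donors or acceptors, produces a step beyond the scatter, whereas the only earlier step, a 1.6-fold higher number from compound 1 to compound 2 (0.20 log units; within the scatter), involved a sulfonamide nitrogen. No evidence is available on what lies behind this step.

The compounds shown do not tell whether this step is particular to fluoro or would also come with another group on this carbon, such as chloro, methyl or methoxy. They also leave open whether fluoro at this position would have the same effect alongside the ethyl group of compound 2.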